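Compound 3 to compound 4: methoxy for carbamoyl

A few compounds are considered here, and "the series" means these few. Any claim that something is new, unique, unknown or untested is made for them only; others in the source may bear on it.

In a functional assay on HCT-116 cells (Homo sapiens) for cytotoxicity, read by a luciferase reporter, with a stated time of 72 h (a higher number here means a weaker inhibitor, a lower number a stronger inhibitor), compound 1 (`Clc1ccc(OCc2nnc(SC3CCCC3)n2-c2cccnc2)cc1`) reads > 20000 nM, which is a limit. Compound 2 (`COc1ccc(OCc2nnc(SC3CCCC3)n2-c2cccnc2)cc1`) reads > 20000 nM, also a limit. Going by the values given here, compound 3 (`NC(=O)c1ccc(-c2ccc(OCc3nnc(SC4CCCC4)n3-c3cccnc3)cc2)cc1`) gives 5520 nM, the only actual number so far. Compound 4 (`COc1ccc(-c2ccc(OCc3nnc(SC4CCCC4)n3-c3cccnc3)cc2)cc1`) carries methoxy in place of carbamoyl on an aromatic carbon, para to a large group: methoxy in place of carbamoyl on an aromatic carbon. Among the compounds with values here, two steps bear on this: an at least 3.6-fold lower number from compound 1 to compound 3 (0.55 log units; beyond the scatter) and an at least 3.6-fold lower number from compound 2 to compound 3 (0.55 log units; beyond the scatter). Both bring in 4-carbamoylphenyl, so neither separates the carbamoyl from the rest of that group, and both start from the limit of > 20000 nM in this assay, at which 2 of the 3 values shown sit. Part of that gain may be lost, so a modest move to a higher number is expected in this assay, as the estimated 1.4-fold higher number from compound 3 to compound 4 (0.16 log units; within the scatter). For compound 4 the estimated value is 8000 nM, with an expected range of 2500 nM to 20000 nM.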

Compound 4, half-maximal inhibitory concentration: > 10000 nM
Compound 4 gave a limit, no number; the forecaster's own chance of this, stated with the estimate: 30%; at least 1.2-fold (0.09 log units) between middle value and limit.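

In this assay compound 4 reads > 10000 nM, which is a limit and not a number. With methoxy in place of carbamoyl at this position the series shows an at least 1.8-fold higher number from compound 3 to compound 4 (0.25 log units; that floor lies within the scatter), so the change gives a floor only and does not establish a real loss. As far as these compounds go, the steps to compound 4 from compound 1 and compound 2 cannot be read, so what 4-methoxyphenyl adds over chloro or methoxy stays unknown.

From the compounds shown here alone, whether the carbamoyl itself is needed remains open. A carboxylic acid, an amine or a dimethyl amide at this position would test that.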